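The source may report more compounds than this note shows. Statements on the series, on what has been measured and on what is new or still open speak of the compounds shown alone.

Working notes on the series, step from compound 2 to compound 3.

Two members of the series have been run in a functional assay on 786-0 cells (Homo sapiens) for inhibition, read by sulforhodamine B assay, with a stated time of 48 h, tested at 10 uM; on this read-out higher numbers stand for a weaker effect at the one concentration tested and lower numbers for a stronger effect. Compound 1 `COc1cc(Cl)cc(-c2nn(-c3cccc(NC(=O)c4ccc(Cl)c(Cl)c4)c3)cc2-c2ccncc2)c1` gives 74.1% in this assay. Going by the values given here, compound 2 `COc1cc(Cl)cc(-c2nn(-c3cccc(NC(=O)Nc4ccc(Cl)c(Cl)c4)c3)cc2-c2ccncc2)c1` gives 19.6% in this assay, the lowest of the two numbers recorded so far; the single measured step, a number 54.5 percentage points lower from compound 1 to compound 2 (beyond the scatter), separates them and places compound 2 well beyond the scatter from compound 1.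

Compound 3 `COc1cc(Cl)cc(-c2nn(-c3cccc(NC(=O)c4cccc(C(F)(F)F)c4)c3)cc2-c2ccncc2)c1` has not yet been measured. Its relation to compound 2 is 3-(trifluoromethyl)phenyl in place of (3,4-dichlorophenyl)amino on a carbonyl carbon. Among the compounds with values here, the only measured step that bears on this change is the one from compound 1 to compound 2, in which the (3,4-dichlorophenyl)amino group entered on the carbonyl carbon and the number fell by a number 54.5 percentage points lower from compound 1 to compound 2 (beyond the scatter). Compound 3 undoes that kind of change: the group with the amino link leaves the carbonyl carbon and a plain aryl group, 3-(trifluoromethyl)phenyl, enters in its place, so a large step in the opposite direction is expected, a number 45.4 percentage points higher from compound 2 to compound 3 (beyond the scatter), back toward the region of compound 1, whose aryl group on the same carbonyl carbon differs from that of compound 3, which is the source of most of the uncertainty. For compound 3 the estimate in this assay is therefore 65%, within a range from 40% to 90%.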

Compound 3, a percentage reported as activity, at one concentration (the size of the read-out at that concentration, not a potency): 66.6%
Estimate against measurement, compound 3: 1.6 percentage points below; the measured number falls inside the stated range.
By their numbers in this assay, from the lowest: compound 2; then compounds 3 and 1 (each within the scatter of the next).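

In this assay, the move away from the (3,4-dichlorophenyl)amino group on the carbonyl carbon gives a number 47 percentage points higher from compound 2 to compound 3 (beyond the scatter) and now sets a second plain aryl group against that amino-linked group, so the low number of compound 2 stands apart from two compounds with an aryl group directly on the carbonyl carbon. Exchanging the aryl group at that position gives a number 7.5 percentage points lower from compound 1 to compound 3 (within the scatter), so 3-(trifluoromethyl)phenyl and 3,4-dichlorophenyl cannot be told apart here, and the large steps on either side of compound 2 do not depend on which of these two aryl groups is present. No measurement accompanies these steps that would explain them.

Going by these compounds, it remains open whether (3-(trifluoromethyl)phenyl)amino on the same carbonyl carbon would give a number as low as compound 2, which would show how far the amino link holds with a different aryl group. On these data alone, it is also open whether a 3,4-dichlorophenoxy group or a 3,4-dichlorobenzyl group on that carbonyl carbon would stay near compound 2 or near compound 1 and compound 3.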